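The compounds below may be only part of what the source reports. "The series", "measured", "known", "first", "only" and "open" are said of these compounds alone.

Working notes on the alkoxymethylamino series built on the shared core, tested in a functional assay on K562 cells (Homo sapiens) for cytotoxicity, read by MTT assay, with a stated time of 72 h; a higher number here means a weaker inhibitor, a lower number a stronger inhibitor.

Three compounds have numbers. Compound 1 `CCCCCOCNc1n[n+]([O-])c2ccccc2[n+]1[O-]` gives 3300 nM. Compound 2 `CC(C)CCOCNc1n[n+]([O-])c2ccccc2[n+]1[O-]` gives 5850 nM. Compound 3 `CCCCOCNc1n[n+]([O-])c2ccccc2[n+]1[O-]` gives 3240 nM, the lowest of the three numbers; its nearest neighbour is compound 1, the step being a 1.0-fold lower number from compound 1 to compound 3 (0.01 log units; within the scatter), and the step from compound 2 is a 1.8-fold lower number from compound 2 to compound 3 (0.26 log units; within the scatter), so no order among the three is established.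

Compound 4 `CCCCCCCOCNc1n[n+]([O-])c2ccccc2[n+]1[O-]` has not been measured. It differs from compound 3 by propyl in place of hydrogen on a saturated chain carbon, four bonds along the chain from an oxygen on a saturated carbon. The measured steps that bear on this are the chain changes already seen: a 1.0-fold lower number from compound 1 to compound 3 (0.01 log units; within the scatter) is a methyl removed at the place named in the change and is the reverse direction of the present extension, while a 1.8-fold higher number from compound 1 to compound 2 (0.25 log units; within the scatter) and a 1.8-fold lower number from compound 2 to compound 3 (0.26 log units; within the scatter) cover the branching pattern of the chain. All three lie within the scatter, and nothing in the set shows chain length moving the number.

The expected step is therefore a 1.0-fold higher number from compound 3 to compound 4 (0.01 log units; within the scatter), that is, no movement beyond the scatter. Compound 4 is estimated at 3300 nM, with a range from 1400 nM to 8000 nM; a somewhat wider range is kept because the extension goes further than any chain measured so far.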

Compound 4, half-maximal inhibitory concentration: 6170 nM
The estimate for compound 4 lay 1.9-fold (0.27 log units) below the measured number; measured number inside the range.
By their numbers in this assay, from the lowest: compounds 3, 1, 2 and 4 (each within the scatter of the next).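

In this assay, within the data shown here, propyl in place of hydrogen on a saturated chain carbon, four bonds along the chain from an oxygen on a saturated carbon, gives a 1.9-fold higher number from compound 3 to compound 4 (0.28 log units; within the scatter) and is the largest extension at this place so far, yet the step stays inside the scatter. The other two new steps, a 1.1-fold higher number from compound 2 to compound 4 (0.02 log units; within the scatter) and a 1.9-fold higher number from compound 1 to compound 4 (0.27 log units; within the scatter) likewise stay inside it, so the branched chain of compound 2 and the longest straight chain, in compound 4, are not told apart. Across these four compounds, then, neither extending the chain nor branching it has been shown to move the number, and no order among them is established. No measurement at hand bears on this flat response.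

Still open, on these data alone, is whether a much longer chain such as decyl, or a shorter one such as ethyl, would produce a step beyond the scatter. Also open, as far as these compounds go, is whether an amine or a carboxylic acid at the end of the chain, or a phenyl ring in place of the chain, would change the number on the shared core.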